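Removing the methoxy group from compound 2

The compounds below may be only part of what the source reports. "The series", "measured", "known", "first", "only" and "open" are said of these compounds alone.

Compound 1 `COc1ccc(CNc2nc([Se]C)nc3ccccc23)cc1`: > 100000 nM
Compound 2 `COc1ccc(CNc2nc([SeH])nc3ccccc23)cc1`: > 100000 nM
Compound 3 `C[Se]c1nc([Se]C)c2cccnc2n1`: "not determined" (no result reported)

In a functional assay on CCRF-CEM cells (Homo sapiens) for cytotoxicity, read by MTT assay, with a stated time of 72 h (on this read-out lower numbers stand for stronger inhibition of growth and higher numbers for weaker inhibition of growth), compound 1 gives only a limit of the assay, > 100000 nM. Compound 2 likewise gives only a limit, > 100000 nM. For compound 3 no result was reported, "not determined" (no result reported). Among the compounds with values here, the single step between measured neighbours, a step that the two limits leave unreadable from compound 1 to compound 2, cannot be read because of the limit of > 100000 nM in this assay, at which 2 of the 3 values shown sit. Compound 2 therefore stands at the limit, with no readable step around it.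

Compound 4 `[SeH]c1nc(NCc2ccccc2)c2ccccc2n1` differs from compound 2 by hydrogen in place of methoxy on an aromatic carbon. Within the data shown here, no measured step bears on this change, so the expectation rests on where compound 2 stands. Compound 4 is expected to remain at the limit, a step of a number no higher from compound 2 to compound 4 (the limit leaves the size open). The estimate for compound 4 is 100000 nM, between 30000 nM and 300000 nM.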

Compound 4, concentration for total growth inhibition: > 100000 nM
Compound 4: no number, only a limit; the forecaster's own chance of this, stated with the estimate: 75%; the middle value sits exactly at the limit.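

The step between compound 2 and compound 4 cannot be read, because both give only a limit and not a number: the limit of > 100000 nM in this assay, at which 3 of the 4 values shown sit. From the compounds shown here alone, whether hydrogen in place of methoxy changes growth inhibition at all stays open.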